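Swapping the aryl group in a stable pair

The source may report more compounds than this note shows. Statements on the series, on what has been measured and on what is new or still open speak of the compounds shown alone.

Of the compounds shown here, two have been measured so far in an ADME assay on microsomes from liver (Mus musculus) for metabolic stability, read by LC-MS, with NADPH named in the record, with a stated time of 60 min, tested at 1 uM, in the absence of a further agent (on this read-out higher numbers stand for a more stable compound and lower numbers for a less stable compound), and neither gives a number. Compound 1 `COc1ccc(-c2c(C)sc3c(N4CC[C@@H](NC(C)=O)C4)nc(C)nc23)cc1OC` reads > 95% as a limit of the assay. Compound 2 `COc1cc(-c2c(C)nc3c(N4CC[C@@H](NC(C)=O)C4)cc(C)nn23)ccc1F` reads > 95% as a limit too, so its true position is not resolved and any measurable move from it is expected to be downward. For the measured compounds named here, the evidence amounts to the limit of > 95% in this assay, at which 2 of the 2 values shown sit, and no step between measured compounds that differ in one place is available.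

Compound 3 `CC(=O)N[C@@H]1CCN(c2cc(C)nn3c(-c4nccs4)c(C)nc23)C1` is still to be measured. Its difference from compound 2 is 1,3-thiazol-2-yl in place of 4-fluoro-3-methoxyphenyl on an aromatic carbon and it places 1,3-thiazol-2-yl in place of 4-fluoro-3-methoxyphenyl on an aromatic carbon of a five-membered aromatic ring with 2 nitrogen. Going by the values given here, with no measured step as a guide, the expected step of a number at least 7 percentage points lower from compound 2 to compound 3 (that floor lies within the scatter) is a small one towards lower stability, and it may well stay within the usual scatter. The estimated value for compound 3 is 88% within an expected range of 68% to 98% for this measurement.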

Compound 3, percent of the compound remaining: > 95%
Compound 3 ended at the assay's limit; the forecaster's own chance of this, stated with the estimate: 40%; middle value at least 7 percentage points away from the limit.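

In this assay compound 3 gives > 95% as a limit of the assay. Compound 2 also stands at a limit, so the step from compound 2 to compound 3 cannot be read. The compounds shown leave open whether compound 1, compound 2 and compound 3 differ in stability at all, the evidence being only this: the limit of > 95% in this assay, at which 3 of the 3 values shown sit.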